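Fluoro for Methyl on the Benzyl Ring of Compound 3

The source may hold more compounds than are shown below. What is called first, only, known or untested is meant among the compounds shown, and "the series" means these compounds.

Measured so far in an assay on CHO cells for displacement of a labelled ligand from adenosine receptor A1 (Homo sapiens); a higher number here means a weaker inhibitor, a lower number a stronger inhibitor:
Compound 1, `O=C(Nc1ncc(C(=O)O)c2nc(-c3ccco3)nn12)NC1CCCCC1`, reaches only the assay limit > 100000 nM.
Compound 2, `CCNc1ncc(C(=O)O)c2nc(-c3ccco3)nn12`, gives 11900 nM.
Compound 3, `Cc1ccc(CNc2ncc(C(=O)O)c3nc(-c4ccco4)nn23)cc1`, gives 2730 nM.

Compound 3 stands lowest of the two numbers, with compound 2 nearest; the step of a 4.4-fold lower number from compound 2 to compound 3 (0.64 log units; beyond the scatter) lies beyond the scatter. Compound 4, `O=C(O)c1cnc(NCc2ccc(F)cc2)n2nc(-c3ccco3)nc12`, differs from compound 3 by fluoro in place of methyl on an aromatic carbon. For the measured compounds named here, none of the measured steps alters a substituent on that ring: an at least 8.4-fold lower number from compound 1 to compound 2 (0.92 log units; beyond the scatter) and an at least 36-fold lower number from compound 1 to compound 3 (1.56 log units; beyond the scatter) replace the whole group on the ring nitrogen. Since only a 4.4-fold lower number from compound 2 to compound 3 (0.64 log units; beyond the scatter) touches the benzyl part, and it brings in the whole 4-methylphenyl, a swap of one atom on that ring is expected to move the number in this assay by no more than the scatter, a 1.1-fold higher number from compound 3 to compound 4 (0.04 log units; within the scatter). Compound 4 is estimated at 3000 nM, between 1000 nM and 9000 nM.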

Compound 4, inhibition constant: > 100000 nM
Compound 4: a limit, no number; the forecaster's own chance of this, stated with the estimate: 5%; middle value at least 33-fold (1.52 log units) away from the limit.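

The swap of one atom on the benzyl ring is no small change in this assay: fluoro in place of methyl gives an at least 36-fold higher number from compound 3 to compound 4 (1.56 log units; beyond the scatter) at this place, para to a large group. 4-Fluorobenzyl also falls behind ethyl on the ring nitrogen, with an at least 8.4-fold higher number from compound 2 to compound 4 (0.92 log units; beyond the scatter) and so the advantage of the 4-methylbenzyl group does not carry over to its fluoro counterpart. Compound 4 is a limit and not a number, and the step involving compound 1 cannot be read: the limit of > 100000 nM in this assay, at which 2 of the 4 values shown sit. On these data alone, whether the loss belongs to fluoro alone or follows any loss of the methyl stays open, and chloro, methoxy or plain hydrogen at this place would separate the two.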